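Chloro added to a small pyrazoline amide

The source may report more compounds than this note shows. Statements on the series, on what has been measured and on what is new or still open speak of the compounds shown alone.

Compounds measured so far:
compound 1, `Nc1ccc(Cl)cc1C1=NN(C(=O)c2ccccc2)CC1`, 17%
compound 2, `CCC(=O)N1CCC(c2ccccc2N)=N1`, 6.88%

In an assay on isolated protein for inhibition of Nitric oxide synthase, inducible (Homo sapiens), with a stated time of 30 min, tested at 1 mM (on this read-out higher numbers stand for more inhibition at the one concentration tested (going by the name of the read-out) and lower numbers for less inhibition), compound 2 gives the lowest of the two numbers; compound 1 gives the nearer value, higher by a margin beyond the scatter. Compound 3, `CCC(=O)N1CCC(c2cc(Cl)ccc2N)=N1`, differs from compound 2 by chloro in place of hydrogen on an aromatic carbon, on an aromatic carbon para to an amino group. Going by the values given here, no measured pair shows this change alone, so only a guess is possible. A small upward step is expected, a number 5.1 percentage points higher from compound 2 to compound 3 (within the scatter), likely within the scatter. Compound 3 is thus estimated at 12%, with a range from 2% to 25%.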

Compound 3, a percentage reported as inhibition, at one concentration (the size of the read-out at that concentration, not a potency): 13.7%
For compound 3 the middle estimate is 1.7 percentage points below the measured one; low and high end bracket the measured number.
By their numbers in this assay, from the lowest: compounds 2, 3 and 1 (each within the scatter of the next, the first and the last beyond it).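

In this assay, chloro in place of hydrogen on an aromatic carbon, para to an amino group, gives a number 6.8 percentage points higher from compound 2 to compound 3 (within the scatter) and so cannot be told apart from repeat scatter as a single change. With that chloro kept, ethyl in place of phenyl on a carbonyl carbon gives a number 3.3 percentage points lower from compound 1 to compound 3 (within the scatter) and likewise stays unresolved. Nothing available offers a reason for either step. From the compounds shown here alone, whether bromo or methyl at this same place would read differently remains open, as does a longer chain in place of ethyl on the carbonyl carbon.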